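Sulfonamide nitrogen variants: from compound 3 to compound 4

The compounds below may be only part of what the source reports. "The series", "measured", "known", "first", "only" and "open" are said of these compounds alone.

Measured so far in a functional assay on the whole organism (aorta) with Rattus norvegicus as the target; on this read-out higher numbers stand for larger maximal responses and lower numbers for smaller maximal responses:
compound 1, `CCNS(=O)(=O)c1ccc2c(c1)C(n1ccccc1=O)=CC(C)(C)O2`: 72.4%
compound 2, `CC(C)NS(=O)(=O)c1ccc2c(c1)C(n1ccccc1=O)=CC(C)(C)O2`: 76.9%
compound 3, `COc1ccc(NS(=O)(=O)c2ccc3c(c2)C(n2ccccc2=O)=CC(C)(C)O3)cc1`: 77.9%

All three compounds share one core and differ only in what sits on the sulfonamide nitrogen. The gaps a number 5.5 percentage points higher from compound 1 to compound 3 (within the scatter) and a number 1 percentage points higher from compound 2 to compound 3 (within the scatter) both lie within the scatter, as does a number 4.5 percentage points higher from compound 1 to compound 2 (within the scatter), so on this assay the three compounds cannot be told apart.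

Compound 4, `CN(C)S(=O)(=O)c1ccc2c(c1)C(n1ccccc1=O)=CC(C)(C)O2`, has not been measured yet. Its change from compound 3 is dimethylamino in place of (4-methoxyphenyl)amino on a sulfonyl sulfur. Within the data shown here, the steps that bear on it are those in which the group on the sulfonamide nitrogen was exchanged, a number 5.5 percentage points higher from compound 1 to compound 3 (within the scatter) and a number 1 percentage points higher from compound 2 to compound 3 (within the scatter), and both stayed within the scatter. Among the measured compounds shown here, no measured step removes the hydrogen from the sulfonamide nitrogen, so that part of the change has no precedent here. On the measured steps, the expected step of a number 2.9 percentage points lower from compound 3 to compound 4 (within the scatter) is none beyond the scatter. Compound 4 is therefore estimated to give 75% in this assay, with a range from 62% to 88%.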

Compound 4, largest response reached (Emax), in percent of the reference or control that the assay uses: 78.3%
For compound 4 the middle estimate is 3.3 percentage points below the measured one; the range from low to high includes it.
By their numbers in this assay, from the lowest: compounds 1, 2, 3 and 4 (each within the scatter of the next).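

In this assay, the steps of a number 0.4 percentage points higher from compound 3 to compound 4 (within the scatter), a number 1.4 percentage points higher from compound 2 to compound 4 (within the scatter) and a number 5.9 percentage points higher from compound 1 to compound 4 (within the scatter) leave compound 4 indistinguishable from the other three compounds. Among these compounds, this adds a case the earlier compounds did not cover: on a sulfonyl sulfur, dimethylamino, with no hydrogen-bond donor and no ring, cannot be told apart from the amino groups that carry a hydrogen-bond donor, including (4-methoxyphenyl)amino with its aromatic ring. Nothing at hand explains why these groups read alike.

The compounds shown leave open whether any group on the sulfonyl sulfur can move the maximal response beyond the scatter. A cyclic amine such as morpholine, a chain ending in a carboxylic acid or a longer chain would test this.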